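Side chains on the shared core: isopropyl to 2-carboxyethyl

The source may report more compounds than this note shows. Statements on the series, on what has been measured and on what is new or still open speak of the compounds shown alone.

Values in a functional assay on BXPC-3 cells (Homo sapiens) for antiproliferative activity, read by MTT assay, with a stated time of 24 h; a lower number here means a stronger inhibitor, a higher number a weaker inhibitor:
compound 1 `CCN(CC)CCNC(=O)c1ccc(C(CC)(CC)c2ccc(OCS(=O)(=O)c3ccccc3)c(C)c2)n1CC`: 6270 nM
compound 2 `CCn1c(C(=O)N[C@H](C(=O)O)C(C)C)ccc1C(CC)(CC)c1ccc(OCS(=O)(=O)c2ccccc2)c(C)c1`: 16200 nM
compound 3 `CCn1c(C(=O)N[C@@H](C(=O)O)C(C)C)ccc1C(CC)(CC)c1ccc(OCS(=O)(=O)c2ccccc2)c(C)c1`: 13900 nM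

The number for compound 3 cannot be told apart from that of its configurational partner: a 1.2-fold lower number from compound 2 to compound 3 (0.07 log units; within the scatter). It lies modestly on the weaker side of the basic amide: a 2.2-fold higher number from compound 1 to compound 3 (0.35 log units; beyond the scatter).

Compound 4 `CCn1c(C(=O)N[C@H](CCC(=O)O)C(=O)O)ccc1C(CC)(CC)c1ccc(OCS(=O)(=O)c2ccccc2)c(C)c1` carries 2-carboxyethyl in place of isopropyl on a saturated chain carbon bound to an amide-type nitrogen and a carbonyl carbon. For the measured compounds named here, no measured step changes this group. The closest evidence is the replacement of the whole amide side chain, a 2.6-fold higher number from compound 1 to compound 2 (0.41 log units; beyond the scatter), which was modest, and the configuration swap, which stayed within the scatter. No step beyond the scatter is therefore expected in this assay.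

The estimated step is a 1.2-fold higher number from compound 3 to compound 4 (0.06 log units; within the scatter). Compound 4 is expected at 16000 nM, with an estimated range of 8000 nM to 35000 nM.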

Compound 4, half-maximal inhibitory concentration: > 50000 nM
Compound 4: no number, only a limit (the forecaster's own chance of this, stated with the estimate: 10%); middle value at least 3.1-fold (0.49 log units) from the limit.
By their numbers in this assay, from the lowest: compound 1; then compounds 3 and 2 (each within the scatter of the next). At a limit, above all of these: compound 4.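

In this assay the value of compound 4 is a limit of the assay, not a number: the limit of > 50000 nM in this assay, at which 1 of the 4 values shown sits. At this saturated chain carbon, 2-carboxyethyl in place of isopropyl moves the number beyond the scatter, an at least 3.5-fold higher number from compound 3 to compound 4 (0.55 log units; beyond the scatter), whereas the configuration swap at the same carbon stayed within it. The 1,3-dicarboxypropyl side chain also separates from 1-carboxy-2-methylpropyl, an at least 3.0-fold higher number from compound 2 to compound 4 (0.48 log units; beyond the scatter), and from 2-(diethylamino)ethyl, an at least 7.9-fold higher number from compound 1 to compound 4 (0.90 log units; beyond the scatter).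

As far as these compounds go, the true size of these steps stays open beyond the limit. Also open, from the compounds shown here alone, is how carboxymethyl, or an amine on the same chain in place of the carboxylic acid, would read at this carbon.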